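The source may hold more compounds than are shown below. What is called first, only, known or untested is meant among the compounds shown, and "the series" means these compounds.

Compound 1 `Cc1ccccc1-c1nc(CN2CCC(C(=O)NCCCN3CCC(C(C)C)CC3)CC2)c(C)o1`: 0.147 h
Compound 2 `Cc1ccccc1-c1nc(CN2CCC(C(=O)NCCCN3CCC(C)(C)CC3)CC2)c(C)o1`: > 0.5 h (a limit)
Compound 3 `Cc1ccccc1-c1nc(CN2CCC(C(=O)NCCCN3CCC(C)CC3)CC2)c(C)o1`: > 0.5 h (a limit)

These half-lives come from an ADME assay on microsomes from liver (Rattus norvegicus) for metabolic stability, read by LC-MS, using NADPH, at 37 degrees C; on this read-out higher numbers stand for a longer-lived compound and lower numbers for a shorter-lived compound. Compound 3 is known only through a limit, > 0.5 h. Compound 2 carries the same limit, and the series therefore shows (the limit of > 0.5 h in this assay, at which 2 of the 3 values shown sit).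

Compound 4 `Cc1ccccc1-c1nc(CN2CCC(C(=O)NCCCN3CCCCC3)CC2)c(C)o1` differs from compound 3 as follows: hydrogen in place of methyl on a saturated ring carbon. This is hydrogen in place of methyl on a saturated ring carbon, turning 4-methylpiperidin-1-yl into piperidin-1-yl.

The nearest measured precedent is the same kind of replacement, but it gives no size: a step that the two limits leave unreadable from compound 2 to compound 3. Two further steps can be read in part: an at least 3.4-fold higher number from compound 1 to compound 3 (0.53 log units; beyond the scatter) and an at least 3.4-fold higher number from compound 1 to compound 2 (0.53 log units; beyond the scatter). Both start from the 4-isopropylpiperidin-1-yl group of compound 1, so they bear only loosely on the loss of a single methyl. Among the compounds with values here, in both, the smaller group goes with the longer half-life, and no compound here goes against that, although the step between the two limits cannot be read.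

No change beyond the scatter is therefore expected in this assay, with any drift more likely upward. The expected step is a step that the limit leaves unreadable from compound 3 to compound 4. The estimate for compound 4 is 0.6 h, with an expected range from 0.3 h to 1.2 h.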

Compound 4, half-life: > 0.5 h
Compound 4 ended at the assay's limit; the forecaster's own chance of this, stated with the estimate: 60%; the middle value does not contradict the limit.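

Compound 4 shows that this ring carbon needs no carbon substituent at all for this assay to stay at its limit: piperidin-1-yl now sits there alongside 4-methylpiperidin-1-yl and 4,4-dimethylpiperidin-1-yl. Replacing the isopropyl group with hydrogen gives an at least 3.4-fold higher number from compound 1 to compound 4 (0.53 log units; beyond the scatter), so the isopropyl compound remains the only one of the four with a half-life that can be read as a number. The steps from compound 3 to compound 4 and from compound 2 to compound 4 cannot be read, because all three compounds sit at the same limit: the limit of > 0.5 h in this assay, at which 3 of the 4 values shown sit.

Going by these compounds, how far compound 2, compound 3 and compound 4 actually lie beyond that limit stays open, and with it any order among hydrogen, methyl and two methyl groups at this position. Also open, on these data alone, is whether an ethyl group or a hydroxyl group on this ring carbon, or a morpholin-4-yl group in place of piperidin-1-yl, would keep the half-life at the limit or bring it back towards that of compound 1.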